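Swapping a saturated ring for a phenol on the ring nitrogen

The source may hold more compounds than are shown below. What is called first, only, known or untested is meant among the compounds shown, and "the series" means these compounds.

Of the compounds shown here, three sharing one core have been measured in a physicochemical assay for lipophilicity, read by HPLC, at pH 7.4; on this read-out lower numbers stand for lower lipophilicity and higher numbers for higher lipophilicity. Compound 1 `Cc1ccccc1N1C(=O)/C(=C/c2ccc(O)c(Cl)c2)S/C1=N\CCCF` gives 3.4. Compound 2 `CCC/N=C1\S/C(=C\c2ccc(O)c(Cl)c2)C(=O)N1C1CCOCC1` gives 3.7, the second highest of the three numbers, within the scatter of compound 1 and clearly separated from compound 3 `CCC/N=C1\S/C(=C\c2ccc(O)c(C(C)C)c2)C(=O)N1c1ccccc1C`, which gives 4.3. Nothing else ties these three together as single-point changes, so only their values can be compared.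

The next compound, compound 4 `CCC/N=C1\S/C(=C\c2ccc(O)c(Cl)c2)C(=O)N1c1ccccc1O`, is derived from compound 2 by one change: 2-hydroxyphenyl in place of oxan-4-yl on an amide-type nitrogen in a ring

Among the measured compounds shown here, no pair of measured compounds isolates this change. The nearest guide is compound 1, which also carries an aromatic ring on that nitrogen and gives 3.4, a number within the scatter of compound 2. Against that, the entering group brings one hydrogen-bond donor where the leaving group had none. The expected step from compound 2 to compound 4 in this assay is therefore a number 0.40 log units lower from compound 2 to compound 4 (beyond the scatter), a modest decrease. Compound 4 is estimated at 3.3, with a range from 2.7 to 3.9.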

Compound 4, distribution coefficient: 2.7
The estimate for compound 4 lay 0.60 log units above the measured number, and the stated range covers the measured number.
By their numbers in this assay, from the lowest: compound 4; then compounds 1 and 2 (each within the scatter of the next); then compound 3.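

In this assay, 2-hydroxyphenyl in place of oxan-4-yl on the amide-type nitrogen in the ring gives a number 1.00 log units lower from compound 2 to compound 4 (beyond the scatter). Among the compounds shown here, this is the first single change measured, and it shows that the group on this nitrogen can move the read-out beyond the scatter, even though the entering group is one heavy atom larger. No measurement here explains the size of this step.

The change brings in an aromatic ring and a hydrogen-bond donor together, so this one pair cannot divide the step between them. Compounds carrying phenyl or 2-methoxyphenyl on the same nitrogen, with the rest of compound 4 unchanged, would show how much of the step stays without the hydroxyl group, and whether the hydroxyl group itself accounts for most of it.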